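From a trifluoromethoxy to two fluorines on the aniline ring

This account rests on a few compounds, and the source may have more. Where it says the series, first, only, none or still open, it means among the compounds named here.

Of the compounds shown here, three sharing one core have been tested in an assay on isolated protein for inhibition of Dihydrofolate reductase (Homo sapiens), read by spectrophotometry; a lower number here means a stronger inhibitor, a higher number a weaker inhibitor. Compound 1 `CCN(Cc1nc2cc(C(F)(F)F)ccc2nc1-c1ccccc1)c1ccc(F)cc1` gives 3000 nM, compound 2 `CCN(Cc1nc2cc(C(F)(F)F)ccc2nc1-c1ccccc1)c1ccc(OC)cc1` gives 7000 nM, and compound 3 `CCN(Cc1nc2cc(C(F)(F)F)ccc2nc1-c1ccccc1)c1ccc(OC(F)(F)F)cc1` gives 5000 nM. Among these three numbers compound 3 holds the second highest; the step of a 1.4-fold lower number from compound 2 to compound 3 (0.15 log units; within the scatter) and the step of a 1.7-fold higher number from compound 1 to compound 3 (0.22 log units; within the scatter) both lie within the usual scatter, so the three sit close together in this assay.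

Compound 4 `CCN(Cc1nc2cc(C(F)(F)F)ccc2nc1-c1ccccc1)c1ccc(F)c(F)c1` differs from compound 3 by one change: 3,4-difluorophenyl in place of 4-(trifluoromethoxy)phenyl on an amine nitrogen. The step that bears most on this is a 1.7-fold higher number from compound 1 to compound 3 (0.22 log units; within the scatter), a small step within the scatter, since compound 1 already carries one fluoro on that ring. Compound 4 adds a second fluoro to that arrangement; nothing measured here shows the effect of that addition. The step from compound 3 to compound 4 in this assay is therefore expected to be small, a 1.4-fold lower number from compound 3 to compound 4 (0.15 log units; within the scatter), with a slightly lower number as the likelier direction. Compound 4 is estimated at 3500 nM in this assay, with a range from 1500 nM to 8000 nM.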

Compound 4, inhibition constant: 5000 nM
Compound 4: middle estimate off by 1.4-fold (0.15 log units), on the low side; measured number inside the range.
By their numbers in this assay, from the lowest: compounds 1, 3, 4 and 2 (each within the scatter of the next, the first and the last beyond it).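

In this assay, putting 3,4-difluorophenyl in place of 4-(trifluoromethoxy)phenyl on the amine nitrogen gives no change at the digits printed from compound 3 to compound 4 (within the scatter) even though the oxygen is gone and the group has fewer heavy atoms. Adding a second fluoro to the ring of compound 1, a change not seen before, gives a 1.7-fold higher number from compound 1 to compound 4 (0.22 log units; within the scatter) and so cannot be told apart from no effect, while the swap from 4-methoxyphenyl gives a 1.4-fold lower number from compound 2 to compound 4 (0.15 log units; within the scatter) and is just as unclear. No measurement here offers an explanation for these results.

The compounds shown leave open whether a quite different group on this ring, such as an amine or a carboxylic acid, would shift the number beyond the scatter. They also leave open what a longer chain on the amine nitrogen would do.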